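Branching the Propyl Chain of a Simple Amide

The source may report more compounds than this note shows. Statements on the series, on what has been measured and on what is new or still open speak of the compounds shown alone.

Within the data shown here, compound 2 `CCCC(C(N)=O)C(C)C` is one of two compounds measured in a functional assay on the whole organism (strain Sprague-Dawley) with Rattus norvegicus as the target, in the maximal electroshock model; on this read-out lower numbers stand for an effect already at smaller amounts and higher numbers for an effect only at larger amounts of compound. In this assay compound 2 gives 50 mg/kg, and its nearest neighbour, compound 1 `CC(C)C(C(=O)NC(N)=O)C(C)C`, gives 33 mg/kg; the two numbers sit within the usual scatter of each other, so nothing separates them. Compound 3 `CC(C)C(C(N)=O)C(C)C` has not yet been measured. It differs from compound 2 by isopropyl in place of propyl on a saturated chain carbon bound to a carbonyl carbon and a saturated chain carbon. Among the measured compounds shown here, no measured pair shows this change, so the step is expected to stay small, with no clear direction beyond the scatter. Compound 3 is therefore expected to give about 40 mg/kg, between 20 mg/kg and 80 mg/kg.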

Compound 3, dose for half-maximal effect: 51 mg/kg
For compound 3 the middle estimate is 1.3-fold (0.11 log units) below the measured one, within the range that was stated.
By their numbers in this assay, from the lowest: compounds 1, 2 and 3 (each within the scatter of the next).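

In this assay the swap of propyl for isopropyl on a saturated chain carbon bound to a carbonyl carbon and a saturated chain carbon gives a 1.0-fold higher number from compound 2 to compound 3 (0.01 log units; within the scatter) and so shows that this position tolerates either chain shape. Hydrogen in place of carbamoyl on the amide-type nitrogen gives a 1.5-fold higher number from compound 1 to compound 3 (0.19 log units; within the scatter) and so leaves the read-out just as unmoved. No measurement shown here bears on a cause for either result.

The compounds shown leave open whether a longer chain such as butyl at this position would move the number beyond the scatter. They also leave open whether an acetyl group on the amide-type nitrogen would match carbamoyl.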